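A few compounds are considered here, and "the series" means these few. Any claim that something is new, unique, unknown or untested is made for them only; others in the source may bear on it.

Among the measured compounds shown here, compound 2, `CCCCc1[nH]c(=O)c(S(=O)(=O)c2ccc(-c3ccncc3C)cc2)c(O)c1-c1c(OC)cccc1OC`, is the only compound in this set with a reported number: in an ADME assay on microsomes from liver (Homo sapiens) for metabolic stability, using NADPH, with a stated time of 10 min (a lower number here means that less of the compound is left, a higher number that more of the compound is left), compound 2 gives 80%. Compound 1, `CCCCc1[nH]c(=O)c(S(=O)(=O)c2ccc(-c3ccc(F)cc3)cc2)c(O)c1-c1c(OC)cccc1OC`, belongs to the same series, but in this assay compound 1 is recorded as "not determined" (no result reported), so nothing can be said of how compound 1 and compound 2 stand to each other. Compound 3, `CCCCc1[nH]c(=O)c(S(=O)(=O)c2ccc(-c3cccnc3OC)cc2)c(O)c1-c1c(OC)cccc1OC`, has not been measured yet. It differs from compound 2 in a single place: 2-methoxypyridin-3-yl in place of 3-methylpyridin-4-yl on an aromatic carbon. For the measured compounds named here, no measured pair in this set shows what such a swap of one pyridyl ring for another does to the percent remaining, so there is nothing to lean on beyond the single value of compound 2. On that basis compound 3 is expected to stay close to compound 2, with any step from compound 2 to compound 3 of a number 8 percentage points lower from compound 2 to compound 3 (within the scatter) likely lying within the usual scatter. Compound 3 is therefore estimated at 72%, with a range from 50% to 92%.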

Compound 3, percent of the compound remaining: 72%
Estimate against measurement, compound 3: no gap at the digits printed; measured number inside the range.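

In this assay the change from 3-methylpyridin-4-yl to 2-methoxypyridin-3-yl, on an aromatic carbon para to a large group, gives a number 8 percentage points lower from compound 2 to compound 3 (within the scatter). Among the compounds shown here, this is the first step readable at this position, and it shows that moving the ring nitrogen and exchanging the methyl for a methoxy together leave compound 2 and compound 3 indistinguishable in this measurement. Nothing given here explains this result.

The two changes are made together, so the share of each cannot be separated, and with no number for compound 1 the comparison with a ring of carbon only stays closed. On these data alone, it also remains open how this position would respond to a pyridine bearing an amine or a carboxylic acid, or to a longer chain on the pyridine ring.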